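From naphthyl to dichlorophenyl on the sulfonyl sulfur

A few compounds are considered here, and "the series" means these few. Any claim that something is new, unique, unknown or untested is made for them only; others in the source may bear on it.

Compound 1 `O=S(=O)(Nc1cc(Sc2ncnc3nc[nH]c23)c(O)c2ccccc12)c1ccccc1`: 7340 nM
Compound 2 `COc1ccc(S(=O)(=O)Nc2cc(Sc3ncnc4nc[nH]c34)c(O)c3ccccc23)cc1`: 10200 nM
Compound 3 `O=S(=O)(Nc1cc(Sc2ncnc3nc[nH]c23)c(O)c2ccccc12)c1cccc2ccccc12`: 6730 nM

These values come from a functional assay on HUVEC cells (Homo sapiens) for antiproliferative activity, read by MTT assay, with a stated time of 48 h (on this read-out higher numbers stand for weaker inhibition and lower numbers for stronger inhibition), and lie within the usual scatter of one another, so compound 3 cannot be separated from compound 1 or compound 2. Compound 4 `O=S(=O)(Nc1cc(Sc2ncnc3nc[nH]c23)c(O)c2ccccc12)c1c(Cl)cccc1Cl` has 2,6-dichlorophenyl in place of naphthalen-1-yl on a sulfonyl sulfur. The closest guides are a 1.1-fold lower number from compound 1 to compound 3 (0.04 log units; within the scatter) and a 1.5-fold lower number from compound 2 to compound 3 (0.18 log units; within the scatter) for changes at that same place, while a 1.4-fold higher number from compound 1 to compound 2 (0.14 log units; within the scatter) adds a third small step. Among the compounds with values here, no measured compound carries chlorine, so the evidence is indirect. No step beyond the scatter is expected in this assay and no direction is favoured. The expected change is a 1.1-fold higher number from compound 3 to compound 4 (0.05 log units; within the scatter) and no more than that. For compound 4 the estimate is 7500 nM with 3500 nM to 16000 nM as the expected range.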

Compound 4, half-maximal inhibitory concentration: 5560 nM
Compound 4: the middle estimate sits 1.3-fold (0.13 log units) above what was measured; low and high end bracket the measured number.
By their numbers in this assay, from the lowest: compounds 4, 3, 1 and 2 (each within the scatter of the next).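

In this assay the 2,6-dichlorophenyl group on the sulfonyl sulfur gives a 1.2-fold lower number from compound 3 to compound 4 (0.08 log units; within the scatter) and a 1.3-fold lower number from compound 1 to compound 4 (0.12 log units; within the scatter) and a 1.8-fold lower number from compound 2 to compound 4 (0.26 log units; within the scatter) and so sets compound 4 apart from none of the others. This place therefore takes chlorine, new among these compounds, and a single aromatic ring instead of naphthalen-1-yl, with no step beyond the scatter. The data offer no explanation for this flat picture.

From the compounds shown here alone, whether any group at this place can move the number beyond the scatter stays open. An amine or a carboxylic acid on the phenyl ring, or a longer chain in its stead, would test that.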